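Hexyl and heptyl thienopyrimidinones: growth inhibition on PANC-1

The source may hold more compounds than are shown below. What is called first, only, known or untested is meant among the compounds shown, and "the series" means these compounds.

Measured compounds:
- compound 1 `CCCCCCc1cc2c(=O)n(CCSc3nc(-c4cc(OC)c(OC)c(OC)c4)c(C#N)c(=O)[nH]3)cnc2s1`: 36.5 ug/mL
- compound 2 `CCCCCCc1cc2c(=O)n(CCCSc3nc(-c4cc(OC)c(OC)c(OC)c4)c(C#N)c(=O)[nH]3)cnc2s1`: 28.1 ug/mL
- compound 3 `CCCCCCCc1cc2c(=O)n(CCSc3nc(-c4cc(OC)c(OC)c(OC)c4)c(C#N)c(=O)[nH]3)cnc2s1`: 72.6 ug/mL

All three were run in an ADME assay on PANC-1 cells (Homo sapiens) for inhibition, read by MTT assay; on this read-out lower numbers stand for stronger inhibition of growth and higher numbers for weaker inhibition of growth. Compound 1 and compound 3 differ by one change, (methyl in place of hydrogen on a saturated chain carbon, six bonds along the chain from an aromatic carbon), and this step made a 2.0-fold higher number from compound 1 to compound 3 (0.30 log units; within the scatter). Compound 2 carries a different linker than compound 1; the difference between the two cores is not broken down here. Compound 2 and compound 3 are not connected by a counted step, and all that can be said of that pair is that compound 2 gives 28.1 ug/mL and compound 3 gives 72.6 ug/mL.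

Compound 4 `CCCCCCCc1cc2c(=O)n(CCCSc3nc(-c4cc(OC)c(OC)c(OC)c4)c(C#N)c(=O)[nH]3)cnc2s1` has not yet been measured in this assay. It stands to compound 2 as compound 3 stands to compound 1: the change is methyl in place of hydrogen on a saturated chain carbon, six bonds along the chain from an aromatic carbon, the same change in the same place. Among the compounds with values here, the only precedent for this change is the step from compound 1 to compound 3, and it lay within the scatter. On that single precedent, and on the value of compound 2, 28.1 ug/mL, the step from compound 2 to compound 4 is expected to be of similar size, a 1.8-fold higher number from compound 2 to compound 4 (0.25 log units; within the scatter), though with one example only the direction is not secure. Compound 4 is therefore estimated at 50 ug/mL, with a range from 25 ug/mL to 100 ug/mL.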

Compound 4, concentration for 50% growth inhibition: > 100 ug/mL
Compound 4 ended at the assay's limit; the forecaster's own chance of this, stated with the estimate: 5%; middle value at least 2.0-fold (0.30 log units) away from the limit.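

In this assay compound 4 gives > 100 ug/mL, which is a limit of the assay and not a number. On the core of compound 2, methyl in place of hydrogen on a saturated chain carbon, six bonds along the chain from an aromatic carbon, gives an at least 3.5-fold higher number from compound 2 to compound 4 (0.55 log units; beyond the scatter), so on this core the change weakens inhibition of growth by more than the scatter. The series therefore shows the change carried onto two cores, but it does not show that the size of the step on one core predicts its size on the other, nor that the two sizes truly differ: the same change on two cores in this assay, a 2.0-fold higher number (0.30 log units; within the scatter) from compound 1 to compound 3 and an at least 3.5-fold higher number (0.55 log units; beyond the scatter) from compound 2 to compound 4; the limit leaves it open whether they differ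

Within the data shown here, how far the step from the hydrogen to the methyl compound on the core of compound 2 really reaches stays open, and the limit touches only one compound in the set: the limit of > 100 ug/mL in this assay, at which 1 of the 4 values shown sits. Also open is how a chain longer than heptyl, or a chain carrying an amine or a carboxylic acid, would read in this assay on either core.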